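The compounds below may be only part of what the source reports. "The series", "measured", "known", "first", "only" and "open" are said of these compounds alone.

In a functional assay on MCF7 cells (Homo sapiens) for inhibition, read by colorimetric assay and MTT assay, with a stated time of 72 h (on this read-out higher numbers stand for weaker inhibition and lower numbers for stronger inhibition), compound 1 `Cn1c2cnc1OCCCCCCCCCCCOc1ccccc1-2` gives 41000 nM as its half-maximal inhibitory concentration. Compound 2 `COc1ccccc1-c1cnc(OC)n1C` yields only a limit (> 100000 nM) and no number in this assay. Compound 3 `C=CCCCCOc1ncc(-c2cc(C(C)C)ccc2OC)n1C` gives 18000 nM in this assay and so holds the lower of the two actual numbers. Compound 1, its nearest neighbour, stands higher by a gap beyond the usual scatter.

Compound 4 `C=CCCCCOc1ncc(-c2cc(C(F)(F)F)ccc2OC)n1C` has not yet been measured. It differs from compound 3 in one place, with trifluoromethyl in place of isopropyl on an aromatic carbon, meta to a large group and para to a methoxy group (trifluoromethyl in place of isopropyl on an aromatic carbon). For the measured compounds named here, no pair of measured compounds differs at this place alone, so the data offer no direct precedent for the swap. One group with no ring and no net charge gives way to another of the same kind. The expectation in this assay is therefore a modest step, quite possibly none beyond the scatter, leaning slightly towards a higher number than compound 3 gives at 18000 nM in the same test. The estimate amounts to a 1.2-fold higher number from compound 3 to compound 4 (0.09 log units; within the scatter) as an expected step. Compound 4 is expected at 22000 nM in a range from 9000 nM to 55000 nM on this estimate.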

Compound 4, half-maximal inhibitory concentration: 61000 nM
Compound 4: middle estimate off by 2.8-fold (0.44 log units), on the low side; measured number outside the range, above it.
By their numbers in this assay, from the lowest: compound 3; then compounds 1 and 4 (each within the scatter of the next). At a limit, above all of these: compound 2.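

At the place on an aromatic carbon, meta to a large group and para to a methoxy group, the choice of group proves to matter in this assay: trifluoromethyl in place of isopropyl gives a 3.4-fold higher number from compound 3 to compound 4 (0.53 log units; beyond the scatter). For the compounds shown here, this is the first change in the set that can be read at a single place, as the earlier compounds offered no such pair. Neither group carries a ring, a hydrogen-bond donor or acceptor, or a net charge, so these counts do not separate isopropyl from trifluoromethyl, and the step shows that matching them does not keep the number unchanged at this place.

With only two groups compared, at this one place and in this one assay, the compounds shown leave open whether an amine, a carboxylic acid, a methyl group or a simple hydrogen here would give a lower or a higher number than isopropyl. How far the number can rise through such changes also stays open, since the read-out of this series can end in a limit rather than a number: the limit of > 100000 nM in this assay, at which 1 of the 4 values shown sits.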